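The source may report more compounds than this note shows. Statements on the series, on what has been measured and on what is new or still open speak of the compounds shown alone.

Compound 1 `CC(C)CC1n2cncc2CN(CC2CC2)S1(=O)=O`: 19%
Compound 2 `CC(C)CC1n2cncc2CN(Cc2ccccc2)S1(=O)=O`: 14%

In an assay on isolated protein for inhibition of Aromatase (Homo sapiens), tested at 1 uM (a higher number here means more inhibition at the concentration tested (going by the name of the read-out), a lower number less inhibition), compound 2 cannot be told apart from compound 1: the step of a number 5 percentage points lower from compound 1 to compound 2 (within the scatter) lies within the scatter, so both give weak inhibition. Compound 3 `CC(C)CC1n2cncc2CN(Cc2ccc(F)cc2)S1(=O)=O` differs from compound 2 by fluoro in place of hydrogen on an aromatic carbon. Among the compounds with values here, no measured step touches a hydrogen on this ring, so none bears directly on the change; the only step known, a number 5 percentage points lower from compound 1 to compound 2 (within the scatter), replaced the whole group bound to the sulfonamide nitrogen and still stayed within the scatter. Compound 3 is therefore expected to stay close to compound 2, a step of no change at the digits printed from compound 2 to compound 3 (within the scatter). The estimate for compound 3 is 14%, between 2% and 30%.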

Compound 3, a percentage reported as inhibition, at one concentration (the size of the read-out at that concentration, not a potency): 39%
Beside the measured number, compound 3's estimate is 25 percentage points below it, and the stated range ends below it.
By their numbers in this assay, from the lowest: compounds 2 and 1 (each within the scatter of the next); then compound 3.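

In this assay the change from phenyl to 4-fluorophenyl gives a number 25 percentage points higher from compound 2 to compound 3 (beyond the scatter) and shows that this aromatic carbon, para to a large group, responds to a single fluoro even though swapping cyclopropyl for phenyl did not shift the reading beyond the scatter. The fluorinated ring also separates from cyclopropyl, with a number 20 percentage points higher from compound 1 to compound 3 (beyond the scatter) on the same shared core. Nothing available here explains this effect of fluoro. As far as these compounds go, it remains open whether fluoro is special at this carbon or whether chloro, methoxy or a nitrile would do the same. From the compounds shown here alone, the effect of fluoro on the other carbons of the ring also remains open.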